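The compounds below may be only part of what the source reports. "The series", "measured", "known", "first", "only" and "open" are said of these compounds alone.

Values in an assay on RAW264.7 cells for inhibition of serine/threonine-protein kinase TBK1 (Mus musculus), read by ELISA, with stated times of 30 min and 6 h; a higher number here means a weaker inhibitor, a lower number a stronger inhibitor:
compound 1 `CC(C)n1cc(Nc2ncc(C3CC3)c(NCCCNC(=O)C3CCC3)n2)cn1`: 81 nM
compound 2 `O=C(NCCCNc1nc(Nc2cccnc2)ncc1C1CC1)C1CCC1`: > 1000 nM; this is a limit of the assay, not a number
compound 3 `CN(C)Cc1ccc(Nc2ncc(C3CC3)c(NCCCNC(=O)C3CCC3)n2)cc1`: 550 nM

Compound 3 gives the highest of the two numbers shown; its nearest neighbour is compound 1, and a 6.8-fold higher number from compound 1 to compound 3 (0.83 log units; beyond the scatter). Compound 2 sits at the limit (the limit of > 1000 nM in this assay, at which 1 of the 3 values shown sits), and an at least 1.8-fold lower number from compound 2 to compound 3 (0.25 log units; that floor lies within the scatter), so nothing beyond the scatter separates compound 2 from compound 3.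

Compound 4 `CN1CCN(C(=O)c2ccc(Nc3ncc(C4CC4)c(NCCCNC(=O)C4CCC4)n3)cc2)CC1` is unmeasured. It differs from compound 3 by (4-methylpiperazin-1-yl)carbonyl in place of (dimethylamino)methyl on an aromatic carbon. Going by the values given here, none of the measured steps touches that position: the steps from compound 1 to compound 2 and from compound 1 to compound 3 exchange the whole group on the aromatic nitrogen, and both moved the number upward, an at least 12-fold higher number from compound 1 to compound 2 (1.09 log units; beyond the scatter) and a 6.8-fold higher number from compound 1 to compound 3 (0.83 log units; beyond the scatter). They show that the series is sensitive to what stands on that nitrogen, but give no direction for a change that keeps the phenyl ring and alters only the substituent on its aromatic carbon.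

Compound 4 is therefore expected to stay near compound 3 in this assay, with a step of a 1.3-fold higher number from compound 3 to compound 4 (0.10 log units; within the scatter) that is expected to lie within or only just beyond the scatter. The estimate for compound 4 is 700 nM, with a range from 250 nM to 2000 nM.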

Compound 4, half-maximal inhibitory concentration: "not active" (no number reported)
Compound 4 has no reported number here; no gap can be computed for the estimate.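

Going by these compounds alone, compound 4 is reported as "not active" in this assay, with no number, so no step between compound 3 and compound 4 can be read. The compounds shown leave open how large a change (4-methylpiperazin-1-yl)carbonyl in place of (dimethylamino)methyl brings to the number on this aromatic carbon.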